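The source may report more compounds than this note shows. Statements on the series, on what has been measured and on what is new or still open speak of the compounds shown alone.

Of the compounds shown here, three sharing one core have been tested in a functional assay on A-375 cells (Homo sapiens) for cytotoxicity, read by MTT assay; on this read-out lower numbers stand for stronger inhibition and higher numbers for weaker inhibition. Compound 1 `O=C(NCCCNc1nccc(-c2c(-c3cccc(F)c3)nc3sccn23)n1)c1ccc(F)cc1` carries a (4-fluorophenyl)carbonyl amide on the chain, and in this assay compound 1 gives 14900 nM. Compound 2 `O=S(=O)(NCCCNc1nccc(-c2c(-c3cccc(F)c3)nc3sccn23)n1)c1ccc(C(F)(F)F)cc1` carries a sulfonyl group bearing a trifluoromethyl, and in this assay compound 2 gives 4090 nM. Compound 3 `O=S(=O)(NCCCNc1nccc(-c2c(-c3cccc(F)c3)nc3sccn23)n1)c1ccccc1` carries a plain phenylsulfonyl, and in this assay compound 3 gives 6600 nM, the second highest number of the three. The steps show a 2.3-fold lower number from compound 1 to compound 3 (0.35 log units; beyond the scatter), while a 1.6-fold higher number from compound 2 to compound 3 (0.21 log units; within the scatter).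

Compound 4 `O=C(NCCNc1nccc(-c2c(-c3cccc(F)c3)nc3sccn23)n1)c1ccccc1` is the next member. Compared with compound 3 the change is benzamido in place of ((phenylsulfonyl)amino)methyl on a saturated chain carbon, two bonds along the chain from a nitrogen on an aromatic ring. This reverses the kind of change seen from compound 1 to compound 3, where the amide gave the higher number, and also shortens the chain by one carbon, for which no comparison exists. Within the data shown here, only the step of a 2.3-fold lower number from compound 1 to compound 3 (0.35 log units; beyond the scatter) therefore bears on the expectation, and it was modest. A modest rise in the number is expected for compound 4, about a 1.8-fold higher number from compound 3 to compound 4 (0.26 log units; within the scatter). In this assay compound 4 is estimated at 12000 nM, with a likely range from 4000 nM to 40000 nM.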

Compound 4, half-maximal inhibitory concentration: 5060 nM
Beside the measured number, compound 4's estimate is 2.4-fold (0.38 log units) above it; measured number inside the range.
By their numbers in this assay, from the lowest: compounds 2, 4 and 3 (each within the scatter of the next); then compound 1.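

Moving from the ((phenylsulfonyl)amino)methyl group to benzamido changes the linking group and shortens the chain in a single step, yet in this assay this gives a 1.3-fold lower number from compound 3 to compound 4 (0.12 log units; within the scatter) and so does not separate the two compounds. Among these compounds, the amide link therefore does not by itself bring the high number of compound 1, since the step from the (((4-fluorophenyl)carbonyl)amino)methyl group to benzamido, which keeps an amide, gives a 2.9-fold lower number from compound 1 to compound 4 (0.47 log units; beyond the scatter) and is the first step among the amides, though still a modest one. No measurement of any other kind is available to account for either step.

This last step removes the ring fluorine and shortens the chain together, and no compound shown changes only one of these, so their separate contributions remain open. A plain benzamide on the longer chain, a phenylsulfonyl group on the shorter chain, or a still longer chain would help separate them, and a free primary amine at the chain end would test whether the aromatic ring on the chain matters at all.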